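Chloro for Methoxy on the Outer Aryl Ring of Compound 1

A few compounds are considered here, and "the series" means these few. Any claim that something is new, unique, unknown or untested is made for them only; others in the source may bear on it.

Compound 1: `COc1ccc(-c2cs/c(=N\NC(=O)c3ccc(O)cc3)n2-c2ccc(OC)cc2OC)cc1` — in a functional assay on Malme-3M cells (Homo sapiens) for cytotoxicity, read by sulforhodamine B assay, with a stated time of 48 h (a higher number here means that more compound is tolerated, a lower number that less compound is tolerated), compound 1 gives < 100000 nM, a limit of the assay rather than a number.
Compound 2: `O=C(c1ccc(O)cc1)n1nc(-c2c(Cl)cccc2Cl)sc1=S` — in this assay compound 2 gives < 100000 nM, also a limit.
Compound 3: `Cc1ccc(-c2cs/c(=N\NC(=O)c3ccc(O)cc3)n2-c2c(C)cccc2C)cc1` — in this assay compound 3 gives < 100000 nM, again a limit.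

Compound 1 therefore stands at the limit itself, and the limit of < 100000 nM in this assay, at which 3 of the 3 values shown sit, leaves nothing to separate it from the other two. Compound 4 `COc1ccc(-n2c(-c3ccc(Cl)cc3)cs/c2=N\NC(=O)c2ccc(O)cc2)c(OC)c1` differs from compound 1 by chloro in place of methoxy on an aromatic carbon. Among the compounds with values here, no step between measured compounds has been measured, so the size of this change cannot be read from the data; an effect no larger than the scatter is expected. Compound 4 is estimated at 40000 nM, within 8000 nM to 100000 nM. That expectation corresponds to a step that the limit leaves unreadable from compound 1 to compound 4.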

Compound 4, concentration lethal to 50% of the cells: < 100000 nM
Compound 4: no number, only a limit; the forecaster's own chance of this, stated with the estimate: 65%; the middle value is on the limit's open side.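

Within the data shown here, compound 1 and compound 4 each give only a limit of the assay, so no step between them can be read. In this assay the compounds shown leave open whether chloro in place of methoxy changes the result at all.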